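This account rests on a few compounds, and the source may have more. Where it says the series, first, only, none or still open, it means among the compounds named here.

Measured so far in a functional assay on A549 cells (Homo sapiens) for inhibition, read by CCK-8 assay, with a stated time of 72 h, tested at 8 uM; a higher number here means more inhibition of growth at the concentration tested, a lower number less inhibition of growth:
- compound 1 `COc1ccc(SCc2ccc(/C=C/C(=O)Nc3ccccc3N)cc2)cc1OC`: 80.6%
- compound 2 `Cc1cc(C)cc(SCc2ccc(/C=C/C(=O)Nc3ccccc3N)cc2)c1`: 47.3%

Of the two measured compounds, compound 2 holds the lower number, 47.3%, and the gap to compound 1 lies beyond the scatter.

The next entry is compound 3 `Nc1ccccc1NC(=O)/C=C/c1ccc(CSc2ccc(Cl)cc2)cc1`. The change from compound 2 is 4-chlorophenyl in place of 3,5-dimethylphenyl on a sulfur, with the rest of the structure shared.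

Among the measured compounds shown here, only one measured step bears on this: a number 33.3 percentage points lower from compound 1 to compound 2 (beyond the scatter), a large drop on replacing 3,4-dimethoxyphenyl with 3,5-dimethylphenyl at the same sulfur. That step shows that the group on the sulfur can move the number well beyond the scatter. For the measured compounds named here, it says little about direction here, since no measured compound carries 4-chlorophenyl. Going by the values given here, with compound 2 at 47.3%, the lower of only two numbers, a moderate rise is expected, with a fall not excluded. The expected change is a number 10.7 percentage points higher from compound 2 to compound 3 (beyond the scatter). For compound 3 the estimate is 58%, with an expected range of 36% to 80%.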

Compound 3, percent growth inhibition at one concentration: 59.6%
The estimate for compound 3 lay 1.6 percentage points below the measured number; low and high end bracket the measured number.
By their numbers in this assay, from the lowest: compound 2; then compound 3; then compound 1.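

In this assay, 4-chlorophenyl on the sulfur gives an intermediate result, with a number 12.3 percentage points higher from compound 2 to compound 3 (beyond the scatter) but also a number 21 percentage points lower from compound 1 to compound 3 (beyond the scatter). This position therefore does more than separate one high group from one low group: all three groups differ beyond the scatter, and 3,4-dimethoxyphenyl in compound 1 remains the highest. Both groups without oxygen, in compound 2 and compound 3, fall below it, although this holds for only these three compounds, and nothing available explains their order.

The step from 3,5-dimethylphenyl to 4-chlorophenyl changes the kind, number and placement of the ring substituents together, so the contribution of each remains unresolved. Going by these compounds, it is also open whether unsubstituted phenyl, a single methoxy group, or a ring bearing an amine or a carboxylic acid would fall within this range or outside it, and whether the order would hold if the sulfur were replaced by an oxygen.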